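The compounds below may be only part of what the source reports. "The series", "measured", "known", "first", "only" and "open" are said of these compounds alone.

Measured so far in an ADME assay on S9 fraction from liver (Rattus norvegicus) for metabolic stability, read by LC-MS, using NADPH, with a stated time of 30 min; on this read-out lower numbers stand for a less stable compound and higher numbers for a more stable compound:
compound 1 `CCCCCCCCc1ccc(OCC(=O)Cn2cnnn2)cc1` gives 22%
compound 2 `CCCCCCCCc1ccc(OCC(=O)Cn2nnc(-c3ccc(S(=O)(=O)N(C)C)cc3)n2)cc1` gives 65%
compound 3 `CCCCCCCCc1ccc(OCC(=O)Cn2nnc(C(=O)O)n2)cc1` gives 52%

Compound 1 has the lowest number of the three; compound 3 lies nearest to it, compound 2 furthest, and both gaps lie beyond the scatter. Compound 4 `CCCCCCCCc1ccc(OCC(=O)Cn2nnnc2-c2ccncc2)cc1` is not yet measured. Its change from compound 1 is pyridin-4-yl in place of hydrogen on an aromatic carbon, sitting on an aromatic carbon of the five-membered ring with four nitrogen atoms, between two ring nitrogen atoms.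

Within the data shown here, two measured steps bear on this. a number 30 percentage points higher from compound 1 to compound 3 (beyond the scatter) shows that placing a group on that ring carbon raises the number. a number 13 percentage points lower from compound 2 to compound 3 (beyond the scatter) shows that an aryl group on that carbon gives a higher number than carboxy. Both point the same way: a substituent on the ring carbon, and an aryl one in particular, is expected to lift compound 4 above compound 1 by a modest to sizeable step, a number 30 percentage points higher from compound 1 to compound 4 (beyond the scatter). For compound 4 the estimate in this assay is 52%, within 32% to 72%.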

Compound 4, percent of the compound remaining: 24%
The estimate for compound 4 lay 28 percentage points above the measured number, outside the stated range (below it).
By their numbers in this assay, from the lowest: compounds 1 and 4 (each within the scatter of the next); then compound 3; then compound 2.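

In this assay, pyridin-4-yl in place of hydrogen on this aromatic carbon, with the 1H-tetrazol-1-yl attachment of compound 1 kept, gives a number 2 percentage points higher from compound 1 to compound 4 (within the scatter), so the two compounds cannot be told apart. A substituent on this carbon therefore does not by itself carry the gain seen in a number 30 percentage points higher from compound 1 to compound 3 (beyond the scatter), a step that also replaced 1H-tetrazol-1-yl with a 2H-tetrazol-2-yl attachment. No measurement shown here explains this result.

Going by these compounds, whether a carboxylic acid or a plain phenyl at this place, with the 1H-tetrazol-1-yl attachment, would likewise match compound 1 remains open. Also open, on these data alone, is how pyridin-4-yl would read on the 2H-tetrazol-2-yl attachment, which would separate the effect of the group from that of the attachment.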